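Series notes: halo to methyl swap on the aryl ring

The source may hold more compounds than are shown below. What is called first, only, known or untested is meant among the compounds shown, and "the series" means these compounds.

Measured so far in a functional assay on C6 cells (Rattus norvegicus) for cytotoxicity, read by MTT assay, with a stated time of 24 h, tested at 50 ug/mL; on this read-out lower numbers stand for a stronger effect and higher numbers for a weaker effect at the one concentration tested:
compound 1 `Cc1nnc(SCC(=O)N/N=c2/scc(-c3ccccc3)n2-c2ccccc2)s1` — 63.9%
compound 2 `O=C(CSc1nnnn1-c1ccccc1)N/N=c1/scc(-c2ccc(Br)cc2)n1-c1ccccc1` — 32%
compound 3 `Cc1nnc(SCC(=O)N/N=c2/scc(-c3ccc(Cl)cc3)n2-c2ccccc2)s1` — 37.9%

Compound 2 sits at the low end of the three numbers. Its gap to compound 3 lies within the scatter, so the two cannot be ordered; its gap to compound 1 lies beyond the scatter, and compound 2 gives the stronger effect of that pair in this assay.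

Compound 4 `Cc1ccc(-c2cs/c(=N/NC(=O)CSc3nnnn3-c3ccccc3)n2-c2ccccc2)cc1` differs from compound 2 in one place: methyl in place of bromo on an aromatic carbon. Among the measured compounds shown here, no measured step exchanges bromo for methyl. For the measured compounds named here, the only measured step on this ring position, a number 26 percentage points lower from compound 1 to compound 3 (beyond the scatter), shows that putting a halogen there lowers the number by a modest amount. Compound 4 keeps a substituent at that position but loses the halogen, so the number is expected to move part of the way back toward compound 1, a rise on the order of a number 13 percentage points higher from compound 2 to compound 4 (beyond the scatter), without reaching compound 1.

The value of compound 4 in this assay is therefore estimated at 45%, within a range of 30% to 62%.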

Compound 4, a percentage reported as activity, at one concentration (the size of the read-out at that concentration, not a potency): 29.5%
For compound 4 the middle estimate is 15.5 percentage points above the measured one; measured number below the stated range.
By their numbers in this assay, from the lowest: compounds 4, 2 and 3 (each within the scatter of the next); then compound 1.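

In this assay the 4-bromophenyl to 4-methylphenyl change gives a number 2.5 percentage points lower from compound 2 to compound 4 (within the scatter), so compound 2 and compound 4 cannot be ordered. Among the compounds shown here, until now the only step at this position was a number 26 percentage points lower from compound 1 to compound 3 (beyond the scatter), which left open whether a low number here called for a halogen; compound 4 shows that, with its side chain, a low number does not require one, since methyl and bromo cannot be told apart on this aromatic carbon. Nothing available accounts for this result.

Still open, on these data alone, is whether hydrogen on this aromatic carbon would give a higher number with the side chain of compound 2, as it does with that of compound 1. As far as these compounds go, it is also open whether an amine, a carboxylic acid or a longer chain there would keep the number where compound 2 and compound 4 stand.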